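The source may report more compounds than this note shows. Statements on the series, on what has been measured and on what is new or still open speak of the compounds shown alone.

In a functional assay on KYSE-410 cells (Homo sapiens) for antiproliferative activity, read by MTT assay, with a stated time of 72 h (a lower number here means a stronger inhibitor, a higher number a weaker inhibitor), the measured compounds are these:

Compound 1 `O=C(Nc1cccc(F)c1)c1cc(=O)[nH]c2cc(-c3ccncc3)ccc12` gives > 20000 nM (a limit)
Compound 2 `Nc1ccc(-c2ccc3c(C(=O)Nc4cccc(F)c4)cc(=O)[nH]c3c2)cc1` gives > 20000 nM (a limit)

Compound 2 stands at the limit of > 20000 nM in this assay, at which 2 of the 2 values shown sit, and has no number of its own. Compound 3 `O=C(Nc1cccc(F)c1)c1cc(=O)[nH]c2cc(-c3ccc(F)c(CO)c3)ccc12` differs from it by 4-fluoro-3-(hydroxymethyl)phenyl in place of 4-aminophenyl on an aromatic carbon and so carries 4-fluoro-3-(hydroxymethyl)phenyl in place of 4-aminophenyl on an aromatic carbon. Going by the values given here, the one measured step that bears on this change is a step that the two limits leave unreadable from compound 1 to compound 2 and it offers no size to carry over. Among the compounds with values here, no step of known size or direction can therefore be expected in this assay and a further limit is the likeliest outcome. The expected change is a number no higher from compound 2 to compound 3 (the limit leaves the size open) and this is only an estimate. For compound 3 the expected half-maximal inhibitory concentration is 20000 nM with an estimated range from 6000 nM to 50000 nM.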

Compound 3, half-maximal inhibitory concentration: > 20000 nM
Compound 3: only a limit was reported (the forecaster's own chance of this, stated with the estimate: 65%); the middle value lies on the limit itself.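

In this assay, going by these compounds alone, compound 3 gives > 20000 nM as a limit, and no step from compound 1 or compound 2 to compound 3 can be read. The compounds shown leave open whether pyridin-4-yl, 4-aminophenyl and 4-fluoro-3-(hydroxymethyl)phenyl differ at all in this assay here.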